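A Methoxy Swap in a Tightly Grouped Series

The source may report more compounds than this note shows. Statements on the series, on what has been measured and on what is new or still open speak of the compounds shown alone.

Of the compounds shown here, three built on a shared core have been measured in a functional assay on the whole organism for inhibition, with Rattus norvegicus as the target; a higher number here means a weaker inhibitor, a lower number a stronger inhibitor. Compound 1 (`COc1ccc(OC)c(C2=NOC(=O)/C2=C\c2cccs2)c1`) gives 7900 nM, compound 2 (`O=C1ON=C(c2cccs2)/C1=C/c1ccco1`) gives 5800 nM, and compound 3 (`O=C1ON=C(c2cccs2)/C1=C/c1ccc(F)cc1`) gives 4800 nM. Compound 3 therefore lies within the scatter of both other compounds, and the three cannot be ranked.

Compound 4 (`COc1ccc(/C=C2\C(=O)ON=C2c2cccs2)cc1`) has methoxy in place of fluoro on an aromatic carbon. Among the compounds with values here, no measured pair isolates a single change, so this swap has no direct precedent. Within the data shown here, the nearest guide is compound 1, the only measured compound with methoxy groups, which stands at 7900 nM, within the scatter of compound 3. On that basis, no change beyond the scatter is expected in this assay, and neither direction is favoured. The expected step is a 1.1-fold higher number from compound 3 to compound 4 (0.06 log units; within the scatter), which would remain within the scatter. Compound 4 is estimated at 5500 nM, with an expected range of 2800 nM to 11000 nM.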

Compound 4, half-maximal inhibitory concentration: 2500 nM
For compound 4 the middle estimate is 2.2-fold (0.34 log units) above the measured one; measured number below the stated range.
By their numbers in this assay, from the lowest: compounds 4, 3, 2 and 1 (each within the scatter of the next, the first and the last beyond it).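

With methoxy in place of fluoro on an aromatic carbon, para to a large group, the series gains its first comparison that differs in one place: a 1.9-fold lower number from compound 3 to compound 4 (0.28 log units; within the scatter) in this assay is the whole effect of the swap. This position therefore accepts methoxy, which has more heavy atoms than fluoro and brings a hydrogen-bond acceptor, with no step beyond the scatter, so the data do not separate the two groups here. Nothing available bears on why the swap gives a step of this size.

As far as these compounds go, whether an amine, a carboxylic acid or a longer chain at this position would move the number beyond the scatter remains open. The compounds shown also leave open whether the same swap would give a step of similar size on the rest of compound 1 or compound 2.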